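The source may report more compounds than this note shows. Statements on the series, on what has been measured and on what is new or still open speak of the compounds shown alone.

Compound 1, with the structure `O=C(c1cccnc1)c1ccccc1O`, is one of two compounds that have been measured in a functional assay on IMR-32 cells (Homo sapiens) for cytotoxicity, read by sulforhodamine B assay, with a stated time of 48 h; on this read-out higher numbers stand for weaker inhibition and lower numbers for stronger inhibition. In this assay compound 1 gives 33700 nM, the lower of the two numbers. Among the compounds with values here, compound 2, with the structure `C=CCOc1c(Cl)cccc1C(=O)c1cccnc1`, gives in this assay 94000 nM, a number that lies beyond the usual scatter above that of compound 1; the two structures differ in more than one place, so no single step can be drawn between them. Compound 3, with the structure `O=C(c1cccnc1)c1cc(Cl)ccc1O`, has not yet been measured in this assay. It differs from compound 1 by chloro in place of hydrogen on an aromatic carbon. Within the data shown here, with no step between measured compounds to draw on, the change is expected to give at most a small step, a 1.3-fold lower number from compound 1 to compound 3 (0.13 log units; within the scatter), toward a lower number, within or close to the scatter. Compound 3 is therefore estimated to give 25000 nM in this assay, with a range from 10000 nM to 60000 nM.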

Compound 3, half-maximal inhibitory concentration: 19500 nM
Estimate against measurement, compound 3: 1.3-fold (0.11 log units) above; the range from low to high includes it.
By their numbers in this assay, from the lowest: compounds 3 and 1 (each within the scatter of the next); then compound 2.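

In this assay, within the data shown here, placing chloro on the aromatic carbon para to the hydroxy group gives a 1.7-fold lower number from compound 1 to compound 3 (0.24 log units; within the scatter), the first step in this set that can be read from a change in one place. The position therefore accepts this single heavy atom with the hydroxy group kept, and the read-out does not move beyond the usual scatter, so compound 3 and compound 1 cannot be ranked against each other. Nothing measured here bears on what lies behind this step.

As far as these compounds go, whether a different group at this position, such as a methoxy group, an amine or a carboxylic acid, would give a step beyond the scatter remains open. So does whether chloro would behave the same way on another carbon of this ring.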